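Neopentyl in place of tert-butyl: an expected permeability step

A few compounds are considered here, and "the series" means these few. Any claim that something is new, unique, unknown or untested is made for them only; others in the source may bear on it.

In an ADME assay on Caco-2 cells (Homo sapiens) for permeability, read by LC-MS, in the apical to basolateral direction, with a stated time of 60 min, at pH 6.5 (on this read-out lower numbers stand for lower permeability and higher numbers for higher permeability), compound 1 `O=C(NCc1cc(Cl)ccc1-n1cnnn1)[C@@H]1C[C@@H]2C[C@@H]2N1C(=O)[C@H](O)CC1CC1` gives 3.6 10^-6 cm/s and compound 2 `CC(C)(C)[C@@H](O)C(=O)N1[C@H](C(=O)NCc2cc(Cl)ccc2-n2cnnn2)C[C@@H]2C[C@@H]21` gives 16 10^-6 cm/s as the higher of the two numbers. Compound 3 `CC(C)(C)C[C@@H](O)C(=O)N1[C@H](C(=O)NCc2cc(Cl)ccc2-n2cnnn2)C[C@@H]2C[C@@H]21` differs from compound 2 by neopentyl in place of tert-butyl on a saturated chain carbon bound to a carbonyl carbon and an oxygen on a saturated carbon in one place, with neopentyl in place of tert-butyl on a saturated chain carbon bound to a carbonyl carbon and an oxygen on a saturated carbon. Within the data shown here, only one measured step bears on this place. It is a 4.4-fold higher number from compound 1 to compound 2 (0.65 log units; beyond the scatter) on going to tert-butyl from cyclopropylmethyl, modest but beyond the scatter. Neopentyl itself has not been measured, so only part of that step is expected to be given back, and with little certainty. The expected change is a 1.6-fold lower number from compound 2 to compound 3 (0.20 log units; within the scatter) in the downward direction, perhaps no larger than the scatter. The estimate for compound 3 is 10 10^-6 cm/s with an expected range from 4 10^-6 cm/s to 24 10^-6 cm/s for this measurement.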

Compound 3, apparent permeability: 25 10^-6 cm/s
Beside the measured number, compound 3's estimate is 2.5-fold (0.40 log units) below it; measured number outside the range, above it.
By their numbers in this assay, from the lowest: compound 1; then compounds 2 and 3 (each within the scatter of the next).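

In this assay, the step of a 1.6-fold higher number from compound 2 to compound 3 (0.19 log units; within the scatter) shows that this position accepts neopentyl in place of tert-butyl with no difference that can be told from the scatter, so the extra carbon of neopentyl leaves no readable mark here. The step of a 6.9-fold higher number from compound 1 to compound 3 (0.84 log units; beyond the scatter) lies beyond the scatter, so the separation from the cyclopropylmethyl of compound 1 now holds for two different groups at this place, not only for tert-butyl. No measurement offered here explains either step.

From the compounds shown here alone, it remains open whether a longer chain than neopentyl would stay level with these two compounds or fall back toward compound 1. Equally open, going by these compounds, is how an amine or a carboxylic acid at the end of this chain would read on the same measurement.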